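Amino-acylsulfonamide in place of the propanoic acid

The compounds below may be only part of what the source reports. "The series", "measured", "known", "first", "only" and "open" are said of these compounds alone.

Compound 1 `CCOc1ccccc1-c1ccc(-c2nc3cnccc3c(C[C@H](C)C(=O)O)c2C#N)cc1` is the anchor of this set. In a physicochemical assay for lipophilicity, read by HPLC, at pH 7.5 (a higher number here means a more lipophilic compound, a lower number a more polar compound), compound 1 gives 2.2, the highest of the three numbers recorded, though compound 2 `CC[C@@H](Nc1c(C#N)c(-c2ccc(-c3ccccc3CO)cc2)nc2cnccc12)C(N)=O` with 2.1 and compound 3 `CC[C@@H](Nc1c(C#N)c(-c2ccc(-c3cccc(C)c3F)cc2)nc2cnccc12)C(=O)O` with 2.1 both sit within the scatter of it, so no order among the three can be claimed. No pair of these compounds differs in one place only, so no single-change step has been measured.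

Compound 4 `CCOc1ccccc1-c1ccc(-c2nc3cnccc3c(N[C@H](CC)C(=O)NS(C)(=O)=O)c2C#N)cc1` is not yet measured. Relative to compound 1 the change is a group of 11 heavy atoms (5 carbon, 2 nitrogen, 3 oxygen, 1 sulfur; no ring) in place of a group of 6 heavy atoms (4 carbon, 2 oxygen; no ring), on an aromatic carbon

The unmeasured compound 4 keeps the rest of the structure of compound 1 unchanged. The group that enters carries more heavy atoms and more donors and acceptors than the group that leaves, and both groups are uncharged in the count. Going by the values given here, nothing among the measured compounds shows what such a swap does in this assay. The step from compound 1 to compound 4 is expected to be small, at most a slight fall, and is estimated as a number 0.20 log units lower from compound 1 to compound 4 (within the scatter), which lies within the scatter. Compound 4 is accordingly expected to give about 2 in this assay, with a range from 1.4 to 2.6.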

Compound 4, distribution coefficient: 2.2
Compound 4: middle estimate off by 0.20 log units, on the low side; low and high end bracket the measured number.
By their numbers in this assay, from the lowest: compounds 2, 3, 1 and 4 (each within the scatter of the next).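

Going by these compounds alone, this is the first step that can be read at a single place. At the aromatic carbon opposite the ring nitrogen, ortho to a cyano group, the amino-acylsulfonamide group takes the place of 2-carboxypropyl, and this assay gives no change at the digits printed from compound 1 to compound 4 (within the scatter). The entering group has 11 heavy atoms, 2 hydrogen-bond donors and 4 hydrogen-bond acceptors against 6, 1 and 1 for the group that leaves, yet with the rest of the structure held, this larger group cannot be told apart from 2-carboxypropyl in this read-out. No measurement to hand gives a reason for this result.

Within the data shown here, the swap alters the attachment atom, the chain and the acidic end together, so the single step cannot show what each part contributes, or whether separate contributions offset one another. Still open, as far as these compounds go, is how this position would read with a tetrazole in place of the acylsulfonamide end, or with a longer chain such as ethyl or propyl in place of the methyl on the sulfonyl group, on the same core.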